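A few compounds are considered here, and "the series" means these few. Any claim that something is new, unique, unknown or untested is made for them only; others in the source may bear on it.

In a functional assay on PC-3 cells (Homo sapiens) for inhibition, read by MTT assay, with a stated time of 72 h (a lower number here means a stronger inhibitor, a higher number a weaker inhibitor), three compounds have been measured: compound 1 `C#CCSc1nc(Nc2ccc(C)cc2)c2ccncc2n1` gives 15700 nM; compound 2 `C#CCSc1nc(Nc2cccc(OC)c2)c2ccncc2n1` gives 17100 nM; compound 3 `C#CCSc1nc(Nc2ccc(OC)cc2)c2ccncc2n1` gives 15100 nM.

All three numbers lie within the scatter of one another, so compound 1 stands level with both, nearest to compound 3 and a little further from compound 2. Going by the values given here, the only single-point step between measured compounds, a 1.0-fold lower number from compound 1 to compound 3 (0.02 log units; within the scatter), stays within the scatter.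

Compound 4 `C#CCSc1nc(Nc2ccccc2O)c2ccncc2n1` differs from compound 1 in one place: 2-hydroxyphenyl in place of 4-methylphenyl on a nitrogen on an aromatic ring. Among the compounds with values here, no measured step swaps the whole aryl group on this nitrogen, and none introduces a hydrogen-bond donor, so nothing beyond the scatter is expected in this assay from this change. Compound 4 is therefore expected near 15000 nM, between 6000 nM and 40000 nM, a step of a 1.0-fold lower number from compound 1 to compound 4 (0.02 log units; within the scatter).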

Compound 4, half-maximal inhibitory concentration: 18700 nM
Compound 4: the middle estimate sits 1.2-fold (0.10 log units) below what was measured; low and high end bracket the measured number.
By their numbers in this assay, from the lowest: compounds 3, 1, 2 and 4 (each within the scatter of the next).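

In this assay, putting 2-hydroxyphenyl in place of 4-methylphenyl on this nitrogen gives a 1.2-fold higher number from compound 1 to compound 4 (0.08 log units; within the scatter) and so leaves the two groups indistinguishable here. Going by these compounds alone, this is the first step to exchange the whole aryl group at this position and the first to bring in a hydrogen-bond donor, and neither change moves the number beyond the scatter. No supporting evidence bears on this result. The compounds shown leave open whether an amine or a carboxylic acid on this aryl ring, or a longer chain in its place, would move the number beyond the scatter.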